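The source may hold more compounds than are shown below. What is called first, only, known or untested is meant among the compounds shown, and "the series" means these compounds.

For the measured compounds named here, compound 2, `CCOc1ccc(NC(=O)c2c(N)n[nH]c2Nc2ccccc2)cc1`, gives 67800 nM in an ADME assay on TERT-RPE1 cells (Homo sapiens) for cytotoxicity, read by resazurin assay, with a stated time of 48 h (on this read-out lower numbers stand for stronger inhibition and higher numbers for weaker inhibition), the only number among the two values shown. Compound 1, `C=CCN/C(SC)=C(/C#N)C(=O)Nc1ccc(OCC)cc1`, reaches only a limit in this assay, > 100000 nM; this is the limit of > 100000 nM in this assay, at which 1 of the 2 values shown sits. Compound 3, `CCNc1[nH]nc(N)c1C(=O)Nc1ccc(OCC)cc1`, differs from compound 2 by ethyl in place of phenyl on a nitrogen on an aromatic ring. Going by the values given here, no measured step of this kind is available, so the expected step of a 1.5-fold higher number from compound 2 to compound 3 (0.17 log units; within the scatter) is small, toward weaker inhibition or none beyond the scatter. Compound 3 is therefore expected to give about 100000 nM, within 40000 nM to 250000 nM.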

Compound 3, half-maximal inhibitory concentration: > 100000 nM
Compound 3 gave a limit, no number; the forecaster's own chance of this, stated with the estimate: 55%; the middle value lies on the limit itself.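

Ethyl in place of phenyl on a nitrogen on an aromatic ring gives the first readable step at this position in this assay: an at least 1.4-fold higher number from compound 2 to compound 3 (0.16 log units; that floor lies within the scatter). The change brings no move toward stronger inhibition, so the phenyl is not required for the weak effect seen here. The value of compound 3 is a limit of the assay and not a number: the limit of > 100000 nM in this assay, at which 2 of the 3 values shown sit.

From the compounds shown here alone, how far compound 3 lies past that limit stays open, and with it whether the step exceeds the scatter. Also open, going by these compounds, is whether a longer chain or a benzyl group on that nitrogen would give a number.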